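The source may hold more compounds than are shown below. What is called first, only, known or untested is meant among the compounds shown, and "the series" means these compounds.

Working notes on the series, cytotoxicity read-out.

Compound 1 `Cc1cc(C)cc(S(=O)(=O)c2c(C(N)=O)[nH]c3ccc(Cl)cc23)c1` is the unsubstituted amide of the shared core. Among the measured compounds shown here, in an ADME assay on MT4 cells (Homo sapiens) for cytotoxicity, read by MTT assay, with a stated time of 5 days (on this read-out lower numbers stand for higher toxicity in this test and higher numbers for lower toxicity in this test), compound 1 gives 13000 nM, the lowest of the three numbers measured so far. Compound 2 `Cc1cc(C)cc(S(=O)(=O)c2c(C(=O)N[C@H]3CCN(CC(N)=O)C3)[nH]c3ccc(Cl)cc23)c1` gives 28100 nM and compound 3 `Cc1cc(C)cc(S(=O)(=O)c2c(C(=O)NC3CN(Cc4cccnc4)C3)[nH]c3ccc(Cl)cc23)c1` gives 36000 nM in this assay. Both amide substituents move the number upward from the parent: a 2.2-fold higher number from compound 1 to compound 2 (0.33 log units; beyond the scatter) and a 2.8-fold higher number from compound 1 to compound 3 (0.44 log units; beyond the scatter). Between the two substituted amides the step is a 1.3-fold higher number from compound 2 to compound 3 (0.11 log units; within the scatter), so the carbamoylmethyl-pyrrolidinyl and the pyridinylmethyl-azetidinyl amides cannot be told apart on this read-out.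

Compound 4 `Cc1cc(C)cc(S(=O)(=O)c2c(C(=O)NC3CN(Cc4ccccc4F)C3)[nH]c3ccc(Cl)cc23)c1` carries 1-(2-fluorobenzyl)azetidin-3-yl in place of hydrogen on an amide-type nitrogen. The bearing steps are the two from the parent to a substituted amide, each modest and each upward, with the azetidinyl case of compound 3 the closer analogue in ring size and in bearing an arylmethyl group on the ring nitrogen. For the measured compounds named here, no measured pair separates a fluorophenyl from a pyridinyl on this position, so that part of the change is uncharted. The expectation for compound 4 is therefore a modest upward step in this assay, estimated as a 2.3-fold higher number from compound 1 to compound 4 (0.36 log units; beyond the scatter). Compound 4 is expected to give about 30000 nM, with a range of 12000 nM to 75000 nM.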

Compound 4, half-maximal cytotoxic concentration: > 238000 nM
Compound 4 gave a limit, no number; the forecaster's own chance of this, stated with the estimate: 20%; at least 7.9-fold (0.89 log units) between middle value and limit.
By their numbers in this assay, from the lowest: compound 1; then compounds 2 and 3 (each within the scatter of the next). At a limit, above all of these: compound 4.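

Compound 4 gives a limit in this assay, not a number, so the steps to it are lower bounds only: the limit of > 238000 nM in this assay, at which 1 of the 4 values shown sits. The 1-(2-fluorobenzyl)azetidin-3-yl group on the amide-type nitrogen gives a large step, an at least 18-fold higher number from compound 1 to compound 4 (1.26 log units; beyond the scatter), where the two earlier substituents gave only modest ones, and it also separates from the carbamoylmethyl-pyrrolidinyl amide, with an at least 8.4-fold higher number from compound 2 to compound 4 (0.92 log units; beyond the scatter), so substituents at this nitrogen are no longer indistinguishable on this read-out as compounds 2 and 3 were. The sharpest new point comes from the change on the saturated chain carbon bound to an amine nitrogen in a ring: with the azetidin-3-yl amide kept, 2-fluorophenyl in place of pyridin-3-yl gives an at least 6.6-fold higher number from compound 3 to compound 4 (0.82 log units; beyond the scatter), so the aryl group alone moves the number beyond the scatter.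

From the compounds shown here alone, what stays open is whether this step belongs to the fluorine or to the carbon-only aromatic ring, a question that an unsubstituted benzyl group on the same ring nitrogen would address. Going by these compounds, how far compound 4 lies beyond its limit also remains open, as does whether a benzyl group on the pyrrolidin-3-yl amide would behave in the same way.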